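A Methyl Group Added on Two Different Cores

The source may hold more compounds than are shown below. What is called first, only, known or untested is meant among the compounds shown, and "the series" means these compounds.

Measured so far:
compound 1 `C/C(=C\c1cc(-c2cccnc2)co1)C(N)=O`: 6620 nM
compound 2 `C/C(=C\c1cc(-c2ccc(C)nc2)co1)C(N)=O`: > 50000 nM, a limit and not a number
compound 3 `C/C(=C\c1cc(-c2ccccc2)cs1)C(N)=O`: > 50000 nM, a limit and not a number

In a functional assay on A549 cells (Homo sapiens) for cytotoxicity, read by CCK-8 assay, with a stated time of 24 h (a lower number here means a stronger inhibitor, a higher number a weaker inhibitor), compound 1 gives 6620 nM. Compound 2 gives only a limit in this assay, namely > 50000 nM. The step of an at least 7.5-fold higher number from compound 1 to compound 2 (0.87 log units; beyond the scatter) goes with the change (methyl in place of hydrogen on an aromatic carbon). This step rests on (the limit of > 50000 nM in this assay, at which 2 of the 3 values shown sit), so its true size is open.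

Compound 3 likewise gives only a limit in this assay, > 50000 nM. The difference between the core of compound 3 and the core of compound 1 is not broken down here.

Compound 4 `C/C(=C\c1cc(-c2ccc(C)cc2)cs1)C(N)=O` has not been measured. It differs from compound 3 by methyl in place of hydrogen on an aromatic carbon. This is the same kind of change as from compound 1 to compound 2, not the same: there the methyl sat on a six-membered aromatic ring with 1 nitrogen, next to the ring nitrogen, whereas here it sits on a six-membered aromatic ring of carbon only. Compound 3 already stands at the limit > 50000 nM. Compound 4 is expected to stay there, the expected step being a step that the limit leaves unreadable from compound 3 to compound 4. Compound 4 is therefore estimated at 80000 nM, between 30000 nM and 300000 nM.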

Compound 4, half-maximal inhibitory concentration: > 50000 nM
Compound 4: only a limit was reported (the forecaster's own chance of this, stated with the estimate: 85%); the middle value is on the limit's open side.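

Compound 4, like compound 3, gives only a limit in this assay, and no size can be read for the step between these two compounds: the limit of > 50000 nM in this assay, at which 3 of the 4 values shown sit.

The compounds shown leave open what the true values of compound 2, compound 3 and compound 4 are, and whether methyl in place of hydrogen changes the number at all on the core of compound 3.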